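The source may report more compounds than this note shows. Statements on the series, on what has been measured and on what is new or still open speak of the compounds shown alone.

Measured in a functional assay on HL-60 cells (Homo sapiens) for inhibition, read by MTT assay, with a stated time of 48 h, tested at 10 uM; a lower number here means less inhibition of growth, a higher number more inhibition of growth at the concentration tested:
Compound 1 `Cc1cc(=O)c2c(O)cc(OC/C=C/c3ccccc3)c([C@H]3CCN(C)C[C@H]3O)c2o1`: 21%
Compound 2 `Cc1cc(=O)c2c(O)c(CN3CCC(Cc4ccccc4)CC3)c(O)c([C@H]3CCN(C)C[C@H]3O)c2o1`: 28%

Going by the values given here, only two compounds have been measured so far, and both sit low on this scale. Compound 2, at 28%, stands within the usual scatter of compound 1, at 21%, so this assay does not separate them. Among the compounds with values here, the two also differ in more than one place, and no measured pair isolates a single change.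

The next compound to be tested is compound 3 `Cc1cc(=O)c2c(O)c(CN3CCCCC3)c(O)c([C@H]3CCN(C)C[C@H]3O)c2o1`, which departs from compound 2 at one site: hydrogen in place of benzyl on a saturated ring carbon. In words, it has hydrogen in place of benzyl on a saturated ring carbon. Within the data shown here, with no measured step to guide the expectation, it rests only on compound 2 at 28% and on the size of the group that leaves. A modest downward move is expected, close to the edge of the scatter, and a result within the scatter would be no surprise. The estimate is a number 10 percentage points lower from compound 2 to compound 3 (within the scatter). For compound 3 the expected value is 18%, with an estimated range from 5% to 32%.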

Compound 3, percent growth inhibition at one concentration: 32%
Compound 3: middle estimate off by 14 percentage points, on the low side; low and high end bracket the measured number.
By their numbers in this assay, from the lowest: compounds 1, 2 and 3 (each within the scatter of the next, the first and the last beyond it).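

Going by these compounds alone, replacing benzyl with hydrogen on the saturated ring carbon, three ring bonds from the ring nitrogen, gives the first comparison of compounds that differ in one place, and in this assay it reads as a number 4 percentage points higher from compound 2 to compound 3 (within the scatter). The result shows that this assay does not separate the compound carrying benzyl, with its six-membered aromatic ring of carbon only, from the compound carrying hydrogen at this position, so the group does not register here as either a gain or a loss. No independent measurement accompanies this step, and nothing shown offers an explanation for the result.

The compounds shown leave open whether a smaller carbon group such as methyl, or a group with a different atom such as a hydroxyl or a primary amine, would read differently at the same ring carbon. They also leave open whether a phenyl group or a longer chain ending in phenyl would be told apart from benzyl, since a single step at a single tested concentration gives no trend for this position.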